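This account rests on a few compounds, and the source may have more. Where it says the series, first, only, none or still open, it means among the compounds named here.

Measured in a physicochemical assay for lipophilicity, in phosphate buffer, measured as octanol-water partition; a higher number here means a more lipophilic compound, a lower number a more polar compound:
- compound 1 `O=C(NC(=S)Nc1ccccc1)Nc1ccc2c(c1)C(=O)C(=O)N2Cc1ccccc1`: 2.48
- compound 2 `O=C(NC(=S)Nc1ccccc1)Nc1ccc2c(c1)C(=O)C(=O)N2Cc1ccccc1Cl`: 3.18

Of the two measured compounds, compound 2 stands higher at 3.18. Compound 3 `COc1ccccc1NC(=S)NC(=O)Nc1ccc2c(c1)C(=O)C(=O)N2Cc1ccccc1Cl` is not yet measured in this assay. It carries methoxy in place of hydrogen on an aromatic carbon, that is, methoxy in place of hydrogen on an aromatic carbon. Among the compounds with values here, the only measured step, a number 0.70 log units higher from compound 1 to compound 2 (beyond the scatter), is chloro in place of hydrogen on an aromatic carbon. Within the data shown here, it is a different substituent, so it bears only loosely on this change, and no methoxy step has been measured. A smaller upward shift, or none beyond the scatter, is therefore expected. The expected step is a number 0.07 log units higher from compound 2 to compound 3 (within the scatter). For compound 3 the estimate is 3.25, with an expected range of 2.85 to 3.65.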

Compound 3, partition coefficient: 3.18
Compound 3: middle estimate off by 0.07 log units, on the high side, within the range that was stated.
By their numbers in this assay, from the lowest: compound 1; then compounds 2 and 3 (each within the scatter of the next).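

In this assay, the change from phenyl to 2-methoxyphenyl gives no change at the digits printed from compound 2 to compound 3 (within the scatter), so methoxy on this aromatic carbon, ortho to a large group, brings no shift beyond the scatter. This differs from the chloro change elsewhere in the series, which gives a number 0.70 log units higher from compound 1 to compound 2 (beyond the scatter), although the two changes sit in different places and are not a direct comparison. No measurement available here explains the result.

Open, from the compounds shown here alone, is whether an amine or a carboxylic acid at this same carbon would shift the number in this assay beyond the scatter. Also open, going by these compounds, is whether methoxy on the other carbons of this ring would behave the same way.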